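This account rests on a few compounds, and the source may have more. Where it says the series, first, only, none or still open, it means among the compounds named here.

Compound 1 `O=C(/C=C/C1=Cc2ccccc2OC1)c1ccccc1Cl`, compound 2 `O=C(/C=C/C1=Cc2ccccc2OC1)c1ccc(Cl)cc1` and compound 3 `O=C(/C=C/C1=Cc2ccccc2OC1)c1ccc([N+](=O)[O-])cc1` share one core and differ only in the aryl ketone. In a functional assay on the whole organism for inhibition, with Mus musculus as the target, with a stated time of 1 h, at a dose of 30 mg/kg by the intraperitoneal route (on this read-out lower numbers stand for less inhibition and higher numbers for more inhibition at the one dose given (going by the name of the read-out)), compound 1 gives 52.3%, compound 2 gives 56.1% and compound 3 gives 50.8%. The move a number 3.8 percentage points higher from compound 1 to compound 2 (within the scatter) and the move a number 5.3 percentage points lower from compound 2 to compound 3 (within the scatter) both stay within the scatter, so compound 3 stands within the scatter of both companions. Compound 4 `Nc1ccc(C(=O)/C=C/C2=Cc3ccccc3OC2)cc1` differs from compound 3 by amino in place of nitro on an aromatic carbon. Among the compounds with values here, no measured step tests this exact change, and the two steps that touch the same ring were both within the scatter, so no step beyond the scatter is expected in this assay. Compound 4 is therefore expected to give about 52%, between 38% and 66%, an estimated change of a number 1.2 percentage points higher from compound 3 to compound 4 (within the scatter).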

Compound 4, a percentage reported as inhibition, in the whole organism at one dose (the size of the read-out at that dose, not a potency): 52.6%
The estimate for compound 4 lay 0.6 percentage points below the measured number, and the stated range covers the measured number.
By their numbers in this assay, from the lowest: compounds 3, 1, 4 and 2 (each within the scatter of the next).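

In this assay, amino in place of nitro on an aromatic carbon, para to a large group, gives a number 1.8 percentage points higher from compound 3 to compound 4 (within the scatter) and amino in place of chloro gives a number 3.5 percentage points lower from compound 2 to compound 4 (within the scatter) so a group with a hydrogen-bond donor is now seen at this place, with both steps within the scatter. The 4-aminophenyl in place of 2-chlorophenyl gives a number 0.3 percentage points higher from compound 1 to compound 4 (within the scatter) and so also stays within the scatter. No evidence is available that bears on this result. As far as these compounds go, whether a carboxylic acid or a longer alkyl chain at this place would also stay within the scatter remains open.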